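The source may hold more compounds than are shown below. What is called first, only, known or untested is meant among the compounds shown, and "the series" means these compounds.

Compound 1 `CCOC(=O)c1c(C)coc1-c1ccc2c(CC)cccc2c1OC` and compound 2 `CCOc1c(-c2occ(C)c2CO)ccc2c(CC)cccc12` share a core and were both tested in a functional assay on MDA-MB-231 cells (Homo sapiens) for cytotoxicity, read by MTT assay, with a stated time of 72 h; a lower number here means that less compound is needed, a higher number that more compound is needed for the effect. Compound 1 gives 3.9 ug/mL, while compound 2 gives 1.4 ug/mL. Of the two numbers measured, compound 1 has the higher one, and the gap to compound 2 lies beyond the usual scatter of repeated measurements.

Compound 3 `CCOCc1c(C)coc1-c1ccc2c(CC)cccc2c1OC` has not yet been measured. It differs from compound 1 in one place: ethoxymethyl in place of ethoxycarbonyl on an aromatic carbon. Going by the values given here, no pair of measured compounds differs by exactly this change, so the size and direction of its effect can only be guessed. The expectation is a step from compound 1 to compound 3 of a 1.3-fold lower number from compound 1 to compound 3 (0.11 log units; within the scatter), which would fall within the scatter. Compound 3 is therefore estimated to give 3 ug/mL, with a range from 1.2 ug/mL to 8 ug/mL.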

Compound 3, concentration for half-maximal effect: 9.1 ug/mL
For compound 3 the middle estimate is 3.0-fold (0.48 log units) below the measured one, and the stated range ends below it.
By their numbers in this assay, from the lowest: compound 2; then compound 1; then compound 3.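

On this aromatic carbon of the five-membered aromatic ring with 1 oxygen, the choice of side group matters. In this assay the change from ethoxycarbonyl to ethoxymethyl gives a 2.3-fold higher number from compound 1 to compound 3 (0.37 log units; beyond the scatter) and so, though modest, the step is a real one, towards needing more compound for the effect. The change takes away the double bond outside the aromatic rings and one hydrogen-bond acceptor, but nothing available here links the step to either loss or to any property of the two groups.

From the compounds shown here alone, it remains open whether a carboxylic acid, an amide or a methyl ester on this carbon would give a number closer to that of compound 1 or that of compound 3. It is also unknown whether the same change would give a similar step with other groups elsewhere on the shared core.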